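This account rests on a few compounds, and the source may have more. Where it says the series, first, only, none or still open, it means among the compounds named here.

Compound 1 `Cc1cc(-c2c(F)cc3c(=O)c(Cc4cccc(O)c4)cn(C4CC4)c3c2F)cc(C)n1` carries a 3-hydroxyphenyl group on a saturated chain carbon bound to an aromatic carbon of the shared core. Within the data shown here, in a functional assay on P388 cells (Mus musculus) for cytotoxicity (a higher number here means a weaker inhibitor, a lower number a stronger inhibitor), compound 1 gives 2200 nM, the higher of the two numbers measured so far. Among the measured compounds shown here, its only neighbour is compound 2 `Cc1cc(-c2c(F)cc3c(=O)c(Cc4c(O)cccc4O)cn(C4CC4)c3c2F)cc(C)n1`, which in this assay gives 250 nM; the step of an 8.8-fold lower number from compound 1 to compound 2 (0.94 log units; beyond the scatter) goes with 2,6-dihydroxyphenyl in place of 3-hydroxyphenyl on that same chain carbon. For the measured compounds named here, compound 3 `COc1ccc(Cc2cn(C3CC3)c3c(F)c(-c4cc(C)nc(C)c4)c(F)cc3c2=O)cc1` has not yet been measured. 4-methoxyphenyl in place of 3-hydroxyphenyl on a saturated chain carbon bound to an aromatic carbon No measured step covers this exchange: the single step known touches the same place but brings in a 2,6-dihydroxyphenyl rather than a 4-methoxyphenyl, so it shows only that the group at this place can shift the number well beyond the scatter, without saying in which direction a methoxy group would take it. Because compound 1 already stands at 2200 nM and the new group keeps no hydrogen-bond donor, compound 3 is expected to come out at or somewhat above compound 1, a step estimated as a 1.6-fold higher number from compound 1 to compound 3 (0.20 log units; within the scatter). Compound 3 is therefore expected to give about 3500 nM in this assay, within a range of 900 nM to 14000 nM.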

Compound 3, half-maximal inhibitory concentration: 21000 nM
For compound 3 the middle estimate is 6.0-fold (0.78 log units) below the measured one; the measured number lies above the stated range.
By their numbers in this assay, from the lowest: compound 2; then compound 1; then compound 3.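

In this assay, the exchange of 3-hydroxyphenyl for 4-methoxyphenyl on the saturated chain carbon gives a 9.5-fold higher number from compound 1 to compound 3 (0.98 log units; beyond the scatter), showing that this place can move the number upward as well as downward, whereas the earlier step had shown only a decrease. Read alongside an 84-fold higher number from compound 2 to compound 3 (1.92 log units; beyond the scatter), the three compounds span a wide range through this one group alone, with the number lowest for 2,6-dihydroxyphenyl, intermediate for 3-hydroxyphenyl and highest for 4-methoxyphenyl, the only one of the three groups without a hydroxy group. No supporting evidence is available to explain this order, and the three compounds establish it only as a trend among themselves.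

The step from compound 1 to compound 3 changes both the oxygen substituent and its place on the phenyl ring, so these two changes cannot be separated; a 4-hydroxyphenyl or a 3-methoxyphenyl group would be needed to tell them apart. As far as these compounds go, it also remains open how an unsubstituted phenyl, a 3-aminophenyl or a 2,6-dimethoxyphenyl group would behave at this place.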